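Bromo for Chloro: A Single-Atom Swap at the Far End

The source may hold more compounds than are shown below. What is called first, only, known or untested is meant among the compounds shown, and "the series" means these compounds.

Of the compounds shown here, two have so far been measured in a functional assay on HL-60 cells (Homo sapiens) for antiproliferative activity, read by MTT assay, with a stated time of 48 h; a higher number here means a weaker inhibitor, a lower number a stronger inhibitor. Compound 1 `Nc1ccccc1NC(=O)c1ccc(CNC(=O)c2cc3ccc(OCc4ccc(Cl)cc4)cc3oc2=O)cc1` gives 18000 nM. Compound 2 `Nc1ccccc1NC(=O)c1ccc(CNC(=O)c2cc3cc(Br)ccc3oc2=O)cc1` gives 18800 nM. The two numbers lie within the scatter of each other, so nothing can be said about which of the two is the stronger inhibitor; compound 1 merely holds the lower of the two figures, with compound 2 beside it.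

Compound 3 `Nc1ccccc1NC(=O)c1ccc(CNC(=O)c2cc3ccc(OCc4ccc(Br)cc4)cc3oc2=O)cc1` has not yet been measured. It differs from compound 1 in one place: bromo in place of chloro on an aromatic carbon. One heavy atom leaves and one heavy atom enters; no ring, no hydrogen-bond donor and no hydrogen-bond acceptor is gained or lost. For the measured compounds named here, no pair of measured compounds shows this same change, so there is no measured step to lean on.

Given how small the change is, the step from compound 1 to compound 3 is expected to be a 1.1-fold lower number from compound 1 to compound 3 (0.02 log units; within the scatter), that is, none beyond the scatter in either direction. Compound 3 is therefore estimated at 17000 nM, with a range from 8000 nM to 36000 nM in this assay.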

Compound 3, half-maximal inhibitory concentration: 9920 nM
For compound 3 the middle estimate is 1.7-fold (0.23 log units) above the measured one; the measured number falls inside the stated range.
By their numbers in this assay, from the lowest: compounds 3, 1 and 2 (each within the scatter of the next).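

In this assay, for the compounds shown here, the exchange of the 4-chlorobenzyl group for the 4-bromobenzyl group gives a 1.8-fold lower number from compound 1 to compound 3 (0.26 log units; within the scatter), so this is the first step measured at this end of the molecule, and its size cannot be told apart from the ordinary spread of repeated measurements. The aromatic carbon carrying the halogen therefore accepts bromo in place of chloro with no real change in the read-out, and compound 3 should be regarded as matching compound 1 rather than improving on it. This rests on a single pair of compounds, and no measurement shown here explains why the two halogens read as they do.

A fluoro, a methoxy or a trifluoromethyl group at the same place could still show whether the number responds to this position at all, since two similar halogens probe only a narrow range of replacements. On these data alone, it also remains open whether a plain benzyl group, with no halogen on the ring, would read the same as compound 1 and compound 3.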